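Ester versus amide on the shared core

This account rests on a few compounds, and the source may have more. Where it says the series, first, only, none or still open, it means among the compounds named here.

Going by the values given here, compound 2 `CCN(CC)C(=O)C1=C(C)NC(=O)NC1c1ccsc1` gives 35% in an assay on membranes from HeLa cells for displacement of a labelled ligand from adenosine receptor A3 (Homo sapiens), read by scintillation counting, with a stated time of 180 min, tested at 1 uM (on this read-out lower numbers stand for less inhibition and higher numbers for more inhibition at the one concentration tested (going by the name of the read-out)), the higher of the two numbers so far, while compound 1 `CC1=C(C(=O)OC(C)(C)C)C(c2ccsc2)NC(=O)N1` gives 1%. Among the compounds with values here, the only measured step, a number 34 percentage points higher from compound 1 to compound 2 (beyond the scatter), came with diethylamino in place of tert-butoxy on a carbonyl carbon. Compound 3 `CC1=C(C(=O)OC2CCCCC2)C(c2ccsc2)NC(=O)N1` carries cyclohexyloxy in place of diethylamino on a carbonyl carbon, so the carbonyl carbon again bears an oxygen-linked group as in compound 1. Because that one step of a number 34 percentage points higher from compound 1 to compound 2 (beyond the scatter) ran the other way, a drop of comparable size is expected for compound 3, a number 27 percentage points lower from compound 2 to compound 3 (beyond the scatter). Compound 3 is therefore estimated at 8%, within 0% to 25%.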

Compound 3, a percentage reported as inhibition, at one concentration (the size of the read-out at that concentration, not a potency): 1%
Compound 3: middle estimate off by 7 percentage points, on the high side; the measured number falls inside the stated range.
By their numbers in this assay, from the lowest: compounds 1 and 3 (each within the scatter of the next); then compound 2.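

In this assay the higher number no longer rests on the tert-butyl ester alone: cyclohexyloxy in place of diethylamino gives the same kind of fall (a number 34 percentage points lower from compound 2 to compound 3 (beyond the scatter)). The two esters cannot be told apart, with cyclohexyl in place of tert-butyl on the oxygen (no change at the digits printed from compound 1 to compound 3 (within the scatter)), so among these three compounds only the diethylamino amide, compound 2, stands out. Nothing available explains this difference.

As far as these compounds go, whether any nitrogen-linked group would do remains open, as a dimethylamino or piperidine amide would show. A free carboxylic acid on the same carbonyl carbon also remains an open case.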